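A few compounds are considered here, and "the series" means these few. Any claim that something is new, unique, unknown or untested is made for them only; others in the source may bear on it.

Measured so far:
Compound 1 `FC(F)(F)c1ccc(CNc2nc(-c3ccccc3C(F)(F)F)nc3ccccc23)cc1` — in an assay on a protein complex for inhibition of ubiquitin carboxyl-terminal hydrolase 1/WD repeat-containing protein 48 (Homo sapiens), read by fluorescence (a lower number here means a stronger inhibitor, a higher number a weaker inhibitor), compound 1 gives 8900 nM.
Compound 2 `FC(F)(F)c1ccccc1-c1nc(NCC#Cc2cccnc2)c2ccccc2n1` — in this assay compound 2 gives 8900 nM.

Compound 1 stands level with compound 2 at the digits shown: the step of no change at the digits printed from compound 1 to compound 2 (within the scatter), in which the whole group on the chain carbon bound to the ring nitrogen was exchanged, lies within the scatter. Compound 3 `FC(F)(F)c1ccccc1-c1nc(NCc2ccc(-c3cccc(Cl)c3)cc2)c2ccccc2n1` has not yet been measured. It differs from compound 1 by 3-chlorophenyl in place of trifluoromethyl on an aromatic carbon. Among the measured compounds shown here, only one measured step exists, and it concerns a different exchange at this same end of the molecule; it showed no movement. For the measured compounds named here, no measured step tests a larger group at this aromatic carbon, so the expectation is a small step at most, in no clear direction, and nothing beyond the scatter in this assay. Compound 3 is therefore estimated at 7500 nM, with a range from 2500 nM to 22000 nM, which corresponds to an expected step of a 1.2-fold lower number from compound 1 to compound 3 (0.07 log units; within the scatter).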

Compound 3, half-maximal inhibitory concentration: 2700 nM
For compound 3 the middle estimate is 2.8-fold (0.44 log units) above the measured one, and the stated range covers the measured number.
By their numbers in this assay, from the lowest: compound 3; then compounds 1 and 2 (each within the scatter of the next).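

Among the compounds shown, this is the only step that lies beyond the scatter: in this assay, putting 3-chlorophenyl in place of trifluoromethyl gives a 3.3-fold lower number from compound 1 to compound 3 (0.52 log units; beyond the scatter), a modest gain. This aromatic carbon, para to a large group, therefore accepts a whole additional aromatic ring without any loss of inhibition, and the number even falls. Nothing available explains why the number moved.

The compounds shown do not separate the contribution of the added ring from that of its chlorine, so it remains open whether a plain phenyl would do as well. Going by these compounds, it is also open whether this position would tolerate something quite different, such as a morpholine ring or a carboxylic acid.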